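Cyclopentyl for butyl on a benzamide-linked purine series

The source may report more compounds than this note shows. Statements on the series, on what has been measured and on what is new or still open speak of the compounds shown alone.

The study compares four compounds that share a core and differ at two places. Compound 1 `CCCCn1cnc2c(Nc3cccc(Cl)c3)nc(NCOCc3ccc(/C=C/C(=O)Nc4ccccc4N)cc3)nc21` and compound 2 `Nc1ccccc1NC(=O)/C=C/c1ccc(COCNc2nc(Nc3cccc(Cl)c3)c3ncn(C4CCCC4)c3n2)cc1` carry the same side chain, while compound 3 `CCCCn1cnc2c(Nc3cccc(Cl)c3)nc(NCOCc3ccc(C(=O)Nc4ccccc4N)cc3)nc21` and compound 4 `Nc1ccccc1NC(=O)c1ccc(COCNc2nc(Nc3cccc(Cl)c3)c3ncn(C4CCCC4)c3n2)cc1` carry a shorter one. The two cores differ as follows: (2-aminophenyl)carbamoyl in place of 2-((2-aminophenyl)carbamoyl)ethenyl on an aromatic carbon.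

In a functional assay on HCT-116 cells (Homo sapiens) for antiproliferative activity, read by CCK-8 assay, with a stated time of 72 h, tested at 8 uM (a higher number here means a stronger effect of the compound at the concentration tested, a lower number a weaker effect), compound 1 gives 10.9%. Compound 2 gives 9.19% in this assay, so that a number 1.7 percentage points lower from compound 1 to compound 2 (within the scatter); the change behind this step is cyclopentyl in place of butyl on an aromatic nitrogen. Compound 3 gives 71.9% in this assay, and a number 61 percentage points higher from compound 1 to compound 3 (beyond the scatter). Compound 3 thus stands highest of the three measured compounds, with both of the others beyond the scatter below it.

Compound 4 has not been measured in this assay. It differs from compound 3 in the same way that compound 2 differs from compound 1: cyclopentyl in place of butyl on an aromatic nitrogen. The place is the same in both pairs, so the change is the same. Since that change left the read-out within the scatter from compound 1 to compound 2, the step from compound 3 to compound 4 is expected to be small as well, a number 5.9 percentage points lower from compound 3 to compound 4 (within the scatter), resting on a number 1.7 percentage points lower from compound 1 to compound 2 (within the scatter). Within the data shown here, compound 4 is therefore estimated to give about 66% in this assay, most likely between 45% and 82%, because compound 3 gives 71.9% and only one such precedent is available.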

Compound 4, a percentage reported as inhibition, at one concentration (the size of the read-out at that concentration, not a potency): 40.6%
Beside the measured number, compound 4's estimate is 25.4 percentage points above it; measured number outside the range, below it.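

In this assay, cyclopentyl in place of butyl on an aromatic nitrogen gives a number 31.3 percentage points lower from compound 3 to compound 4 (beyond the scatter), so the small step seen with the longer side chain does not carry over to the shorter one: the same change on two cores in this assay, a number 1.7 percentage points lower (within the scatter) from compound 1 to compound 2 and a number 31.3 percentage points lower (beyond the scatter) from compound 3 to compound 4, 29.6 percentage points apart, beyond the scatter of two such steps

Read the other way, (2-aminophenyl)carbamoyl in place of 2-((2-aminophenyl)carbamoyl)ethenyl on an aromatic carbon gives a number 31.4 percentage points higher from compound 2 to compound 4 (beyond the scatter), which has the same direction as the step with butyl but not the same size: the same change on two cores in this assay, a number 61 percentage points higher (beyond the scatter) from compound 1 to compound 3 and a number 31.4 percentage points higher (beyond the scatter) from compound 2 to compound 4, 29.6 percentage points apart, beyond the scatter of two such steps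

The two changes therefore do not act independently across these four compounds, but this rests on a single set of four read-outs at one concentration, and it does not show why the two places depend on each other or whether the same would hold for other groups.

The compounds shown leave open whether the fall from compound 3 to compound 4 follows the closed ring or the size of the group, which a pentyl or a cyclohexyl on that nitrogen would help to separate. Also open, from the compounds shown here alone, is how a longer chain in place of the ethenyl part of the side chain would behave with butyl and with cyclopentyl.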